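Hydroxy in place of the side chain on compound 3

The source may hold more compounds than are shown below. What is called first, only, known or untested is meant among the compounds shown, and "the series" means these compounds.

Measured so far in an ADME assay on Vero cells (Chlorocebus sabaeus) for cytotoxicity, read by MTT assay, with a stated time of 72 h; on this read-out lower numbers stand for higher toxicity in this test and higher numbers for lower toxicity in this test:
Compound 1 `CCO/N=C(\C)CN1CCN(c2c(F)cc3c(=O)c(C(=O)O)cn(C4CC4)c3c2OC)CC1C`: 31.3 ug/mL
Compound 2 `COc1c(N2CCN(C/C(C)=N/Nc3ccccc3)C(C)C2)c(F)cc2c(=O)c(C(=O)O)cn(C3CC3)c12`: 11.1 ug/mL
Compound 3 `COc1c(N2CCN(CC/C(C)=N/Nc3ccccc3)C(C)C2)c(F)cc2c(=O)c(C(=O)O)cn(C3CC3)c12`: 62.5 ug/mL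

The data show a 2.0-fold higher number from compound 1 to compound 3 (0.30 log units; within the scatter) and also a 5.6-fold higher number from compound 2 to compound 3 (0.75 log units; beyond the scatter). Compound 3 thus stands level with compound 1 and clear of compound 2 only. Going by the values given here, compound 4 `COc1c(N2CCN(O)C(C)C2)c(F)cc2c(=O)c(C(=O)O)cn(C3CC3)c12` carries a much larger change, (one oxygen atom in place of a group of 12 heavy atoms (10 carbon, 2 nitrogen; one six-membered aromatic ring of carbon only), on an amine nitrogen in a ring), and no measured compound has hydroxy there. Among the compounds with values here, none of the measured steps removes the whole chain, so they bear on this one only loosely. Even so, a 2.8-fold lower number from compound 1 to compound 2 (0.45 log units; beyond the scatter) and the wider a 5.6-fold higher number from compound 2 to compound 3 (0.75 log units; beyond the scatter) show that changes in this chain move the number modestly. A modest step downward is therefore expected in this assay, estimated as a 2.1-fold lower number from compound 3 to compound 4 (0.32 log units; beyond the scatter) here. Compound 4 is estimated at 30 ug/mL, with an expected range from 10 ug/mL to 90 ug/mL.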

Compound 4, half-maximal cytotoxic concentration: 19.7 ug/mL
Compound 4: middle estimate off by 1.5-fold (0.18 log units), on the high side; low and high end bracket the measured number.
By their numbers in this assay, from the lowest: compounds 2, 4, 1 and 3 (each within the scatter of the next, the first and the last beyond it).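

In this assay, the swap of the group of 12 heavy atoms for hydroxy on the amine nitrogen gives a 3.2-fold lower number from compound 3 to compound 4 (0.50 log units; beyond the scatter) and so the longest chain stands clear of hydroxy. Yet the steps to the shorter chains, a 1.8-fold higher number from compound 2 to compound 4 (0.25 log units; within the scatter) and a 1.6-fold lower number from compound 1 to compound 4 (0.20 log units; within the scatter), both lie within the scatter, so on this nitrogen a single oxygen atom reads level with those two chains. Nothing shown gives a reason for these steps. The compounds shown leave open how a plain hydrogen or a methyl group on this amine nitrogen would read. They also leave open whether the ring methyl group matters to these numbers.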